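The source may hold more compounds than are shown below. What is called first, only, known or untested is meant among the compounds shown, and "the series" means these compounds.

The series rests on a carbamate-bearing core. Compound 1 `CCCCNC(=O)Oc1ccc(Cl)cc1C(=O)Nc1cccc(Cl)c1` and compound 2 `CCCCCNC(=O)Oc1ccc(Cl)cc1C(=O)Nc1cccc(Cl)c1` share one core, while compound 3 `CCCCCCCNC(=O)Oc1ccc(Cl)cc1C(=O)Nc1ccc(Cl)c(Cl)c1` carries another; the difference between the two cores is not broken down here. In a physicochemical assay for lipophilicity (on this read-out lower numbers stand for lower lipophilicity and higher numbers for higher lipophilicity), compound 1 gives 4.69, and in this assay compound 2 gives 5.11. The change between them is methyl in place of hydrogen on a saturated chain carbon, four bonds along the chain from an amide-type nitrogen, and it produced a number 0.42 log units higher from compound 1 to compound 2 (beyond the scatter). Compound 3 stands highest of the three measured compounds in this assay, where compound 3 gives 6.5, beyond the scatter above both compound 2 and compound 1.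

Compound 4 `CCCCCCCCNC(=O)Oc1ccc(Cl)cc1C(=O)Nc1ccc(Cl)c(Cl)c1` has not yet been measured. It differs from compound 3 by methyl in place of hydrogen on a saturated chain carbon, seven bonds along the chain from an amide-type nitrogen. Within the data shown here, this is the same kind of change as the one between compound 1 and compound 2, though not the same: there the entering methyl sits four bonds along the chain from an amide-type nitrogen, here it sits seven bonds along the chain from an amide-type nitrogen. The step expected in this assay is a number 0.45 log units higher from compound 3 to compound 4 (beyond the scatter), because the same kind of change earlier gave a number 0.42 log units higher from compound 1 to compound 2 (beyond the scatter), a modest step beyond the scatter. On that basis compound 4 is expected to give about 6.95 in this assay, most likely falling between 6.6 and 7.3.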

Compound 4, partition coefficient: 6.92
Estimate against measurement, compound 4: 0.03 log units above; the measured number falls inside the stated range.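

In this assay the methyl step carried over from one core to the other: the new pair gave a number 0.42 log units higher from compound 3 to compound 4 (beyond the scatter) and the earlier pair gave a number 0.42 log units higher from compound 1 to compound 2 (beyond the scatter) on the core of compound 1, two steps of the same printed size. Among these compounds, this shows only that one kind of change had a matching effect in two single pairs, and it does not establish a rule for the series, since the core and the place of the entering methyl, four bonds along the chain from an amide-type nitrogen in one pair and seven bonds along it in the other, differ together and so cannot be told apart. Nothing in the material shown explains why the two steps match.

The compounds shown leave open whether the same step would appear on a longer chain than that of compound 4, or whether it would survive on a chain carrying an amine or a carboxylic acid. They also leave open how far the difference between the two cores on its own moves the number, as no pair shown differs in the core alone.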